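The source may report more compounds than this note shows. Statements on the series, on what has been measured and on what is new or still open speak of the compounds shown alone.

Compound 1 `CC(C)COc1ccc(-c2cn3c(=O)n(-c4ccccc4)nc3c(N)n2)cc1`: in an assay on cells for displacement of a labelled ligand from adenosine receptor A3 (Homo sapiens), read by scintillation counting, with a stated time of 3 h (a higher number here means a weaker inhibitor, a lower number a stronger inhibitor), compound 1 gives "not determined" (no result reported).
Compound 2 `O=c1[nH]c(-c2ccccc2)cn2c(=O)n(-c3ccccc3)nc12`: compound 2 gives 96 nM.
Compound 3 `COc1ccc(-c2cn3c(=O)n(-c4ccccc4)nc3c(=O)[nH]2)cc1`: compound 3 gives > 30000 nM, which is a limit of the assay and not a number.

Compound 3 therefore stands only at a range, at the limit of > 30000 nM in this assay, at which 1 of the 3 values shown sits. For the measured compounds named here, the one measured step leading to it, an at least 310-fold higher number from compound 2 to compound 3 (2.49 log units; beyond the scatter), was large and beyond the scatter. Compound 4 `O=c1[nH]c(-c2ccc(O)cc2)cn2c(=O)n(-c3ccccc3)nc12` differs from compound 3 by hydrogen in place of methyl on an oxygen on an aromatic ring. Going by the values given here, no measured step tests this exact change; the only evidence is that adding methoxy cost a great deal. Compound 4 is expected to lie between compound 2 and compound 3, so the estimated step of an at least 3.0-fold lower number from compound 3 to compound 4 (0.47 log units; beyond the scatter) points toward a lower number. For compound 4 the estimate in this assay is 10000 nM, in the range 1000 nM to 100000 nM.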

Compound 4, inhibition constant: 207 nM
Compound 4: middle estimate off by 48-fold (1.68 log units), on the high side; the measured number lies below the stated range.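

In this assay, the large loss comes with the methyl, not with the oxygen on the aromatic ring: 4-hydroxyphenyl in place of 4-methoxyphenyl recovers most of it (an at least 140-fold lower number from compound 3 to compound 4 (2.16 log units; beyond the scatter)). Hydroxy in place of hydrogen makes only a modest change (a 2.2-fold higher number from compound 2 to compound 4 (0.33 log units; beyond the scatter)). The size of the first step is only a bound, because compound 3 rests on a limit and not a number: the limit of > 30000 nM in this assay, at which 1 of the 4 values shown sits.

As far as these compounds go, whether ethoxy, an amine or a carboxylic acid at this place would behave like hydroxy or like methoxy remains open.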